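Hydroxamic acid benzothiophenes: phenethyl amide versus aminoalkyl amide

The source may hold more compounds than are shown below. What is called first, only, known or untested is meant among the compounds shown, and "the series" means these compounds.

Measured compounds:
compound 1, `O=C(CCc1ccccc1)Nc1ccc2sc(C(=O)NO)cc2c1`, 4 ug/mL
compound 2, `O=C(CCc1ccccc1)Nc1ccc2cc(C(=O)NO)sc2c1`, 4 ug/mL

Of the compounds shown here, two have been measured in a physicochemical assay for solubility, at pH 7.4; a higher number here means a more soluble compound, a lower number a less soluble compound. Compound 1 gives 4 ug/mL. Compound 2, which places the same amide side chain on the other arrangement of the shared core, gives 4 ug/mL. On these numbers compound 2 stands level with compound 1, the two values lying within the scatter of each other, so nothing can be said of an order between them.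

The next compound, compound 3, `CN(C)CCCC(=O)Nc1ccc2cc(C(=O)NO)sc2c1`, keeps the core and the amide of compound 2 and changes only the far end of the side chain: (dimethylamino)methyl in place of phenyl on a saturated chain carbon, two bonds along the chain from a carbonyl carbon. Going by the values given here, no step between measured compounds covers a change of this kind, so the expected size must be stated as an expectation rather than read from a precedent. The change is expected to move this assay upward by a large step, well beyond the scatter, which the step of a 20-fold higher number from compound 2 to compound 3 (1.30 log units; beyond the scatter) expresses. Compound 3 is therefore estimated at 80 ug/mL, with a range from 15 ug/mL to 400 ug/mL.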

Compound 3, solubility: 1310 ug/mL
Compound 3: the middle estimate sits 16-fold (1.21 log units) below what was measured; measured number outside the range, above it.
By their numbers in this assay, from the lowest: compounds 1 and 2 (each within the scatter of the next); then compound 3.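

Compounds 1 and 2 differ only in the arrangement of the shared core, and they left the two numbers level, so they showed nothing about the far end of the side chain. At that end, on a saturated chain carbon, two bonds along the chain from a carbonyl carbon, putting (dimethylamino)methyl in place of phenyl gives a 330-fold higher number from compound 2 to compound 3 (2.52 log units; beyond the scatter) in this assay and shows that this position can move the read-out by a large amount, while a change in the core arrangement, at least between compounds 1 and 2, did not. Going by these compounds alone, the single change removes an aromatic ring of carbon only and brings in a nitrogen with no ring, and no measurement in hand bears on why the number moves so far.

The compounds shown leave open whether the step follows the dimethylamino nitrogen or the loss of the phenyl ring, which a plain alkyl chain, a cyclohexyl ring, a morpholine or a carboxylic acid at the same place could help to separate. They also leave open whether a shorter or longer chain leading to the amine keeps the step, and whether the same 3-(dimethylamino)propyl amide on the core arrangement of compound 1 behaves alike.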